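A few compounds are considered here, and "the series" means these few. Any claim that something is new, unique, unknown or untested is made for them only; others in the source may bear on it.

Compound 3 `COc1cc(C(=O)/C=C/c2cc(-c3cc(OC)c(OC)c(OC)c3)n[nH]2)cc(OC)c1OC` and the pair compound 2 `COc1ccc(-c2cc(/C=C/C(=O)c3ccc(N)cc3)[nH]n2)cc1OC` and compound 1 `COc1ccc(-c2cc(/C=C/C(=O)c3ccc(N)cc3)[nH]n2)cc1` rest on two different cores, and the difference between the two cores is not broken down here. In a functional assay on SK-MEL-28 cells (Homo sapiens) for inhibition, read by sulforhodamine B assay, with a stated time of 48 h (a lower number here means that less compound is tolerated, a higher number that more compound is tolerated), compound 3 gives 6070 nM, compound 2 gives 21100 nM and compound 1 gives 8570 nM. Against compound 3, compound 1 lies within the scatter, while compound 2 lies beyond it. The change from compound 2 to compound 1 is hydrogen in place of methoxy on an aromatic carbon, and it gave a 2.5-fold lower number from compound 2 to compound 1 (0.39 log units; beyond the scatter). Compound 4 `COc1ccc(-c2cc(/C=C/C(=O)c3cc(OC)c(OC)c(OC)c3)[nH]n2)cc1OC` arises from compound 3 by the same kind of change, (hydrogen in place of methoxy on an aromatic carbon); the surroundings differ in that the place in compound 4 is also meta to a methoxy group. Because a 2.5-fold lower number from compound 2 to compound 1 (0.39 log units; beyond the scatter) was modest, a step of similar size is expected, a 2.0-fold lower number from compound 3 to compound 4 (0.31 log units; beyond the scatter). Compound 4 is therefore estimated at 3000 nM in this assay, with a range from 1200 nM to 8000 nM.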

Compound 4, concentration lethal to 50% of the cells: 10600 nM
Beside the measured number, compound 4's estimate is 3.5-fold (0.55 log units) below it, outside the stated range (above it).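

In this assay, among these compounds, hydrogen in place of methoxy gave a 1.7-fold higher number from compound 3 to compound 4 (0.24 log units; within the scatter), so on this core the change produced no step that stands clear of the scatter. The same change therefore did not carry over with the same outcome from one core to the other: the same change on two cores in this assay, a 2.5-fold lower number (0.39 log units; beyond the scatter) from compound 2 to compound 1 and a 1.7-fold higher number (0.24 log units; within the scatter) from compound 3 to compound 4, 4.3-fold (0.63 log units) apart, beyond the scatter of two such steps. Among the compounds shown here, with only two pairs, this does not show whether the gap follows from the cores themselves or from the surroundings of the place, which in compound 4 is also meta to a methoxy group, and it gives no rule for any further core.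

The compounds shown leave open how these cores would respond if a hydroxyl group, a fluorine atom or a longer ethoxy chain stood in place of the methoxy group.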